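The source may report more compounds than this note shows. Statements on the series, on what has been measured and on what is new or still open speak of the compounds shown alone.

Values in a physicochemical assay for solubility; a higher number here means a more soluble compound, a lower number a less soluble compound:
- compound 1 `O=C(c1cccc(Cl)c1)N1CCC(NS(=O)(=O)c2cc(S(=O)(=O)c3ccccc3)ccc2C(F)(F)F)CC1`: 6300 nM
- compound 2 `N#Cc1cccc(S(=O)(=O)N2CCC(NS(=O)(=O)c3cc(S(=O)(=O)c4ccccc4)ccc3C(F)(F)F)CC2)c1`: 6300 nM

Compound 2 stands level with compound 1. Compound 3 `CC(C)(O)CCN1CCC(NS(=O)(=O)c2cc(S(=O)(=O)c3ccccc3)ccc2C(F)(F)F)CC1` follows from compound 2 by one change: 3-hydroxy-3-methylbutyl in place of (3-cyanophenyl)sulfonyl on an amine nitrogen in a ring. Within the data shown here, the only measured step, no change at the digits printed from compound 1 to compound 2 (within the scatter), exchanged one ring-bearing group on the amine nitrogen for another, so it bears on this change only in part. Among the measured compounds shown here, no measured compound has a group without a ring at this place. In this assay, a rise beyond the scatter is nevertheless expected, its size poorly constrained. The estimated step is a 4.8-fold higher number from compound 2 to compound 3 (0.68 log units; beyond the scatter). For compound 3 the expected value is 30000 nM, with an estimated range of 8000 nM to 100000 nM.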

Compound 3, solubility: 50000 nM
For compound 3 the middle estimate is 1.7-fold (0.22 log units) below the measured one, within the range that was stated.
By their numbers in this assay, from the lowest: compounds 1 and 2 (each within the scatter of the next); then compound 3.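

In this assay, this position on an amine nitrogen in a ring responds to the group it carries: with 3-hydroxy-3-methylbutyl, which has no ring, the result is a 7.9-fold higher number from compound 2 to compound 3 (0.90 log units; beyond the scatter) and a 7.9-fold higher number from compound 1 to compound 3 (0.90 log units; beyond the scatter). Exchanging one ring-bearing group for another gave only no change at the digits printed from compound 1 to compound 2 (within the scatter). No evidence bears on what lies behind the larger steps.

The change removes the ring and the sulfonyl or carbonyl and adds the hydroxyl all at once, and the compounds shown do not separate these parts. As far as these compounds go, whether a plain 3-methylbutyl chain, or a chain ending in an amine or a carboxylic acid, would give a similar step remains open.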